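Fluoro at the pendant phenyl of compound 3

A few compounds are considered here, and "the series" means these few. Any claim that something is new, unique, unknown or untested is made for them only; others in the source may bear on it.

Compound 1 `Nc1cccc(-c2cn3nc(Cc4ccccc4)sc3n2)c1` gives 7400 nM in a functional assay on L1210 cells (Mus musculus) for inhibition, read by cell counting, with a stated time of 2 days; a higher number here means a weaker inhibitor, a lower number a stronger inhibitor. Compound 3 `Nc1cccc(-c2cn3nc(-c4ccccc4)sc3n2)c1` gives 32000 nM in this assay; the change is a 4.3-fold higher number from compound 1 to compound 3 (0.64 log units; beyond the scatter). For compound 2 `COc1ccc(-c2nn3cc(-c4cccc(N)c4)nc3s2)cc1` the result in this assay is only a limit, >= 250000 nM. The step of an at least 7.8-fold lower number from compound 2 to compound 3 (0.89 log units; beyond the scatter) removes the methoxy from the pendant phenyl. For the measured compounds named here, of the two numbers known, compound 3 holds the highest, with compound 1 nearest; the remaining value is a limit (the limit of >= 250000 nM in this assay, at which 1 of the 3 values shown sits).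

Compound 4 `Nc1cccc(-c2cn3nc(-c4ccc(F)cc4)sc3n2)c1` differs from compound 3 by fluoro in place of hydrogen on an aromatic carbon. The step that bears on it is an at least 7.8-fold lower number from compound 2 to compound 3 (0.89 log units; beyond the scatter), which shows a group at this ring position matters, but fluoro is far smaller than methoxy, so in this assay a step within the scatter, or at most a small rise, is expected. The estimated step is a 1.3-fold higher number from compound 3 to compound 4 (0.10 log units; within the scatter). Compound 4 is therefore expected to give 40000 nM, between 15000 nM and 120000 nM.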

Compound 4, half-maximal inhibitory concentration: >= 250000 nM
Compound 4 ended at the assay's limit; the forecaster's own chance of this, stated with the estimate: 10%; at least 6.2-fold (0.79 log units) between middle value and limit.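

Fluoro in place of hydrogen, on the aromatic carbon para to a large group, is enough to take the series from a readable number to the limit of this assay, with an at least 7.8-fold higher number from compound 3 to compound 4 (0.89 log units; beyond the scatter); methoxy in compound 2 is thus not the only group that does so. Against the benzyl of compound 1 the loss is wider, with an at least 33-fold higher number from compound 1 to compound 4 (1.52 log units; beyond the scatter), while the step between compound 2 and compound 4 cannot be read, as both values are limits. Both substituents shown at this position end at that limit: the limit of >= 250000 nM in this assay, at which 2 of the 4 values shown sit.

From the compounds shown here alone, whether the loss extends to chloro, methyl or an amine at this position stays open. Also open, going by these compounds, is whether fluoro on the benzyl of compound 1 would cost as much as it does on the phenyl of compound 3.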